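The compounds below may be only part of what the source reports. "The series", "measured", "known", "first", "only" and "open" are said of these compounds alone.

Measured so far: compound 1 `CCC(=O)OCc1ccc2oc(=O)c(C(=O)Oc3cccc(Br)c3)cc2c1` with 21.3% and compound 2 `CCCCCCC(=O)OCc1ccc2oc(=O)c(C(=O)Oc3cccc(Br)c3)cc2c1` with 36%, both in a functional assay on HT-1080 cells (Homo sapiens), read by transwell migration, with a stated time of 24 h, tested at 10 uM; on this read-out lower numbers stand for a stronger effect and higher numbers for a weaker effect at the one concentration tested.

Compound 2 stands highest of the two numbers, which in this assay means the weaker effect; its nearest neighbour is compound 1, a number beyond the scatter lower. Among the measured compounds shown here, the one measured step, a number 14.7 percentage points higher from compound 1 to compound 2 (beyond the scatter), is a modest shift, and it shows that lengthening the chain on the ester weakened the effect.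

Compound 3 `NCc1ccc2oc(=O)c(C(=O)Oc3cccc(Br)c3)cc2c1` differs from compound 2 as follows: amino in place of (hexylcarbonyl)oxy on a saturated chain carbon bound to an aromatic carbon. For the measured compounds named here, no measured step bears directly on this change; the ester chain that was lengthened in the step from compound 1 to compound 2 is removed altogether here, together with the carbonyl, and an amino group takes its place. Going by the values given here, with only that chain-length step for guidance, the direction is uncertain, but since the shorter chain gave the lower number, the estimate leans toward a number no higher than that of compound 1. For compound 3 a step of a number 11 percentage points lower from compound 2 to compound 3 (beyond the scatter) in this assay is expected, giving an estimated value of 25%, with a wide range from 5% to 60%.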

Compound 3, a percentage reported as activity, at one concentration (the size of the read-out at that concentration, not a potency): 63.6%
Compound 3: middle estimate off by 38.6 percentage points, on the low side; the whole stated range lies below it.
By their numbers in this assay, from the lowest: compound 1; then compound 2; then compound 3.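

In this assay, amino in place of (hexylcarbonyl)oxy gives a number 27.6 percentage points higher from compound 2 to compound 3 (beyond the scatter), and amino in place of propanoyloxy gives a number 42.3 percentage points higher from compound 1 to compound 3 (beyond the scatter). Among the compounds shown here, the earlier compounds showed only that the length of the ester chain changes the effect, whereas these steps show that replacing the whole ester with amino on this saturated chain carbon bound to an aromatic carbon leaves a weaker effect than either ester gives. Nothing available explains why the amino compound behaves this way.

Going by these compounds, what remains open is which part of the ester matters, the carbonyl or the chain. A hydroxymethyl group, which would keep the oxygen without the carbonyl, or an acetamide, which would restore a carbonyl on the nitrogen, could help separate these possibilities.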